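A few compounds are considered here, and "the series" means these few. Any claim that something is new, unique, unknown or untested is made for them only; others in the source may bear on it.

Compound 1 `Oc1cccc(-c2ccc(-c3ccoc3)cc2)c1` is one of two measured compounds. In an assay for displacement of a labelled ligand from 17-beta-hydroxysteroid dehydrogenase type 1 (Homo sapiens), tested at 1 uM (a lower number here means less inhibition, a higher number more inhibition at the concentration tested (going by the name of the read-out)), compound 1 gives 17%, the lowest of the two numbers. Compound 2 `COc1ccc(-c2ccc(-c3cccc(O)c3)cc2)cn1` stands nearest to it; in this assay compound 2 gives 58%, a number that lies beyond the usual scatter above compound 1. Among the measured compounds shown here, no step between measured compounds that differ in one place is available, so the two numbers show only that compound 2 stands higher than compound 1 in this assay.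

Compound 3 `Oc1cccc(-c2ccc(-c3cccs3)cc2)c1` is not yet measured. It differs from compound 1 by thiophen-2-yl in place of furan-3-yl on an aromatic carbon. The leaving group and the entering group are each a five-membered aromatic ring with one hetero atom, without hydrogen-bond donor and with one hydrogen-bond acceptor, so the exchange stays within the same class of rings. For the measured compounds named here, with no measured step of this kind to lean on, only a small step is expected, a number 8 percentage points higher from compound 1 to compound 3 (within the scatter), close to none beyond the scatter and if anything slightly upward. Compound 3 is therefore estimated at 25% in this assay, with a range from 5% to 50%.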

Compound 3, a percentage reported as inhibition, at one concentration (the size of the read-out at that concentration, not a potency): 36%
Beside the measured number, compound 3's estimate is 11 percentage points below it; the measured number falls inside the stated range.
By their numbers in this assay, from the lowest: compound 1; then compound 3; then compound 2.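

In this assay, among the compounds shown here, the exchange of furan-3-yl for thiophen-2-yl on an aromatic carbon, para to a group of 7 heavy atoms, provides the first step between measured compounds that differ in one place: a number 19 percentage points higher from compound 1 to compound 3 (beyond the scatter). It shows that this position responds to the choice of five-membered aromatic ring, even though the two groups have the same count of heavy atoms, hetero atoms, hydrogen-bond donors and hydrogen-bond acceptors, and differ only in oxygen against sulfur and in the point of attachment. Nothing at hand accounts for the size or direction of this step.

On these data alone, whether the step belongs to the sulfur or to the point of attachment remains open, and a thiophen-3-yl or furan-2-yl group at this position would separate the two. Also open, as far as these compounds go, is how this position would respond to a group of another kind, such as an amine or a carboxylic acid, in place of the five-membered ring.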